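Hydroxy for Fluoro on a Shared Core

This account rests on a few compounds, and the source may have more. Where it says the series, first, only, none or still open, it means among the compounds named here.

Measured compounds:
compound 1 `Fc1ccc(OCc2nn3c(-c4ccncc4)nnc3s2)cc1` — 28.5%
compound 2 `O=[N+]([O-])c1cccc(C2=Nn3c(nnc3-c3ccncc3)SC2)c1` — 65.5%

Of the compounds shown here, two have been measured in a functional assay on NCI-H157 cells (Homo sapiens) for antiproliferative activity, read by sulforhodamine B assay, with a stated time of 48 h, tested at 10 uM; on this read-out higher numbers stand for more inhibition of growth at the one concentration tested and lower numbers for less inhibition of growth. Compound 1 `Fc1ccc(OCc2nn3c(-c4ccncc4)nnc3s2)cc1` gives 28.5%, the lowest of the two numbers. Compound 2 `O=[N+]([O-])c1cccc(C2=Nn3c(nnc3-c3ccncc3)SC2)c1` gives 65.5%, a number far above that of compound 1 and beyond the usual scatter. The two compounds differ in more than one place, so no single structural change can be tied to that gap.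

Compound 3 `Oc1ccc(OCc2nn3c(-c4ccncc4)nnc3s2)cc1` has not yet been measured in this assay. It differs from compound 1 in one place: hydroxy in place of fluoro on an aromatic carbon. Among the measured compounds shown here, no measured pair shows this change, so its effect is unknown from the numbers at hand. The step from compound 1 is expected to be small, within the scatter, in either direction, as a number 1.5 percentage points higher from compound 1 to compound 3 (within the scatter). Compound 3 is therefore estimated at 30%, with a range from 10% to 55%.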

Compound 3, percent growth inhibition at one concentration: 60.9%
Beside the measured number, compound 3's estimate is 30.9 percentage points below it; measured number outside the range, above it.
By their numbers in this assay, from the lowest: compound 1; then compounds 3 and 2 (each within the scatter of the next).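

Going from 4-fluorophenyl to 4-hydroxyphenyl on the shared core gives a number 32.4 percentage points higher from compound 1 to compound 3 (beyond the scatter) in this assay, so this position, para to a large group, responds strongly to what it carries: exchanging one heavy atom, fluorine for oxygen, moves the read-out beyond the scatter. Among the compounds shown here, this is the only step here that ties a gap to a single change, whereas the two compounds measured earlier differ in more than one place. No measurement shown here explains the size of this step.

The compounds shown leave open how other groups at this position would read, such as an amine, a methoxy group or a carboxylic acid. They also leave open whether hydroxy in place of fluoro gives a step of this size on another core.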